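The compounds below may be only part of what the source reports. "The series", "measured", "known", "first", "only" and "open" are said of these compounds alone.

In a functional assay on MCF7 cells (Homo sapiens) for cytotoxicity, read by MTT assay (on this read-out higher numbers stand for weaker inhibition and lower numbers for stronger inhibition), two compounds have been read so far: compound 1 (`CCOC(=O)C(C)Oc1cc(O)c2c(=O)c(O)c(-c3ccc(OC)cc3)oc2c1CC=C(C)C`) and compound 2 (`CCOC(=O)C(Oc1cc(O)c2c(=O)c(OC(C(=O)OCC)C(=O)OCC)c(-c3ccc(OC)cc3)oc2c1CC=C(C)C)C(=O)OCC`). Compound 1 gives > 100000 nM, which is a limit of the assay and not a number. Compound 2 gives > 100000 nM, which is also a limit. Compound 1 therefore stands at the limit of > 100000 nM in this assay, at which 2 of the 2 values shown sit, and no measured number anchors the comparison. Compound 3 (`COc1ccc(-c2oc3c(CC=C(C)C)c(OCC(=O)O)cc(O)c3c(=O)c2O)cc1`) differs from compound 1 in one place, with carboxymethyl in place of 1-(ethoxycarbonyl)ethyl on an oxygen on an aromatic ring. For the measured compounds named here, no measured pair shows what such a change does in this assay, so the expectation rests on the two limits alone. The expected change, an at least 1.2-fold lower number from compound 1 to compound 3 (0.09 log units; that floor lies within the scatter), is estimated to lie within the scatter, with no clear direction. Compound 3 is expected at about 80000 nM, within an estimated range of 25000 nM to 200000 nM, and it may be reported only as a limit.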

Compound 3, half-maximal inhibitory concentration: > 100000 nM
Compound 3: a limit, no number; the forecaster's own chance of this, stated with the estimate: 60%; middle value at least 1.2-fold (0.09 log units) from the limit.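

In this assay, for the compounds shown here, compound 3 gives > 100000 nM, which is a limit and not a number, so no step between compound 1 and compound 3 can be read. The compounds shown leave open how they rank and what carboxymethyl in place of 1-(ethoxycarbonyl)ethyl does to a measured number: the limit of > 100000 nM in this assay, at which 3 of the 3 values shown sit.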